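Swapping sulfur for selenium on a phenyl-bearing side chain

The source may report more compounds than this note shows. Statements on the series, on what has been measured and on what is new or still open speak of the compounds shown alone.

In a functional assay on MCF7 cells (Homo sapiens) for cytotoxicity, read by MTT assay, with a stated time of 24 h (a higher number here means a weaker inhibitor, a lower number a stronger inhibitor), compound 1 `CC(C)(C)OC(=O)NCC(=O)OCC(=O)NCCC[Te]c1ccccc1` gives 300 nM. Compound 2 `COc1ccc(N(CC(=O)NCCCSc2ccccc2)C(=O)CCSC2=C(C)C(=O)c3ccccc3C2=O)cc1` gives 16000 nM in this assay, the higher of the two numbers, and its gap to compound 1 is well beyond the scatter of repeated measurements. Compound 3 `COc1ccc(N(CC(=O)NCCCSc2ccccc2)C(=O)CNC(=O)OC(C)(C)C)cc1` reaches only the limit of this assay, >= 100000 nM, which is a boundary of what the method reports rather than a number; this is the situation described in the limit of >= 100000 nM in this assay, at which 1 of the 3 values shown sits. Compound 4 `COc1ccc(N(CC(=O)NCCC[Se]c2ccccc2)C(=O)CCSC2=C(C)C(=O)c3ccccc3C2=O)cc1` has not yet been measured. It differs from compound 2 in a single place: a group of 7 heavy atoms (6 carbon, 1 selenium; one six-membered aromatic ring of carbon only) in place of a group of 7 heavy atoms (6 carbon, 1 sulfur; one six-membered aromatic ring of carbon only), on a saturated chain carbon, three bonds along the chain from an amide-type nitrogen. Within the data shown here, no pair of measured compounds shows this particular change, so there is no measured step to lean on. The expectation for compound 4 is therefore a small step, most likely toward a lower number, of about a 2.0-fold lower number from compound 2 to compound 4 (0.30 log units; within the scatter). Compound 4 is accordingly estimated at 8000 nM, with a plausible range from 2000 nM to 40000 nM.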

Compound 4, half-maximal inhibitory concentration in the MCF7 assay: 8000 nM
Beside the measured number, compound 4's estimate shows no gap at the digits printed, and the stated range covers the measured number.
By their numbers in the MCF7 assay, from the lowest: compound 1; then compounds 4 and 2 (each within the scatter of the next). At a limit, above all of these: compound 3.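

Among these compounds, this is the first measured step at this position: in the MCF7 assay, putting selenium in place of the sulfur of the phenylsulfanyl group gives a 2.0-fold lower number from compound 2 to compound 4 (0.30 log units; within the scatter), so this swap does not clearly separate the two compounds in cell toxicity. In a physicochemical assay for lipophilicity, read by HPLC, measured as octanol-water partition (on this read-out lower numbers stand for lower lipophilicity and higher numbers for higher lipophilicity), compound 2 gives 4.2 and compound 4 gives 4.23, a pair that also lies within the scatter, so neither read-out tells these two compounds apart. Nothing shown gives a cause for either result.

Going by these compounds, compound 1 carries tellurium at the end of its chain but differs from compound 2 in more than one place, so what tellurium would do on the core of compound 2 stays open. Also open, on these data alone, is how a phenoxy group, with oxygen in that place, or a longer chain would behave here.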